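Amide substituent swap in a dithiocarbonate ketone series

The compounds below may be only part of what the source reports. "The series", "measured", "known", "first", "only" and "open" are said of these compounds alone.

Of the compounds shown here, two have a number so far. Compound 1 `COc1ccc(C(=O)CSC(=S)SCCNC(C)=O)cc1` carries an acetamidoethyl group on the sulfur side and a methoxyphenyl ketone; in an assay on HEK293 cells for inhibition of protein deacetylase HDAC6 (Homo sapiens) (a higher number here means a weaker inhibitor, a lower number a stronger inhibitor), compound 1 gives 1640 nM. Compound 2 `CCSC(=S)SCC(=O)c1ccc(C(=O)NCCOc2ccccc2)cc1` instead bears an ethyl group on the sulfur side and an amide on the aryl ring; in this assay compound 2 gives 483 nM, the lowest of the two numbers, and the gap to compound 1 lies beyond the scatter. Among the compounds with values here, the two compounds differ in several places at once, so no single step between them can be read off.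

Compound 3 `CCSC(=S)SCC(=O)c1ccc(C(=O)Nc2ccc(Cl)cc2)cc1` keeps the core of compound 2 and changes only the amide substituent: 4-chlorophenyl in place of 2-phenoxyethyl on an amide-type nitrogen. Nothing measured in the series bears on this change, so no direction is supported by data. The working expectation is a step of about none beyond the scatter, a 1.2-fold higher number from compound 2 to compound 3 (0.09 log units; within the scatter). Compound 3 is therefore estimated at 600 nM in this assay, with a range from 200 nM to 1800 nM.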

Compound 3, half-maximal inhibitory concentration: 1450 nM
Estimate against measurement, compound 3: 2.4-fold (0.38 log units) below; the range from low to high includes it.
By their numbers in this assay, from the lowest: compound 2; then compounds 3 and 1 (each within the scatter of the next).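

In this assay, within the data shown here, the amide nitrogen gives the first single-place change: 4-chlorophenyl in place of 2-phenoxyethyl produces a 3.0-fold higher number from compound 2 to compound 3 (0.48 log units; beyond the scatter) and takes the number beyond the scatter, so the substituent at this position is not indifferent on the shared core. This is a modest step resting on one pair, so it holds for these two groups only and sets no trend across amide substituents. Nothing available bears on the reason for this shift.

The two groups differ at once in the chain, the oxygen and the chlorine, so the pair cannot assign the step to any one of them; an unsubstituted phenyl, a benzyl or a 2-phenylethyl group on the same nitrogen would separate these parts. Also open, from the compounds shown here alone, are how a chain ending in an amine or a carboxylic acid would read at this position, and whether the step would carry over to a core with an acetamidoethyl group in place of the ethyl group on sulfur.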